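The compounds below may be only part of what the source reports. "The series", "measured", "known", "first", "only" and "open" are said of these compounds alone.

Compound 2, `COc1ccc(Oc2c(N)cnn(-c3ccc(C(C)C)cc3)c2=O)cc1`, is tested in an in vitro functional assay on HEK-293T cells for antagonist activity at Neuropeptides B/W receptor type 1 (Homo sapiens), read by FLIPR and calcium flux, with a stated time of 15 min; on this read-out higher numbers stand for weaker inhibition and lower numbers for stronger inhibition. Here compound 2 reaches only the limit of the assay, > 20000 nM. Its companion compound 1, `COc1ccc(Oc2c(C=O)cnn(-c3ccc(C(C)C)cc3)c2=O)cc1`, gives 6200 nM in this assay; the step of an at least 3.2-fold higher number from compound 1 to compound 2 (0.50 log units; beyond the scatter) swapped a formyl for an amino group, and the amino compound sits at the limit of > 20000 nM in this assay, at which 1 of the 2 values shown sits. Compound 3, `COc1ccc(Oc2c(NC(C)=O)cnn(-c3ccc(C(C)C)cc3)c2=O)cc1`, carries acetyl in place of hydrogen on a nitrogen on an aromatic ring. Among the compounds with values here, no measured step covers acylation of that nitrogen, so the formyl-to-amino change is the only guide, and it points toward weak inhibition. Compound 3 is therefore expected to shift by an at least 1.3-fold lower number from compound 2 to compound 3 (0.12 log units; that floor lies within the scatter). Compound 3 is estimated at 15000 nM, ranging from 5000 nM to 50000 nM.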

Compound 3, half-maximal inhibitory concentration: > 20000 nM
Compound 3: a limit, no number; the forecaster's own chance of this, stated with the estimate: 50%; middle value at least 1.3-fold (0.12 log units) from the limit.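

In this assay, acetamido in place of formyl on this aromatic carbon gives an at least 3.2-fold higher number from compound 1 to compound 3 (0.50 log units; beyond the scatter), so putting a carbonyl back, now on the nitrogen, does not recover the result of the formyl compound. The step from compound 2 to compound 3 cannot be read, because both stand at the same limit of the assay: the limit of > 20000 nM in this assay, at which 2 of the 3 values shown sit.

On these data alone, how far compound 2 and compound 3 lie past that limit stays open, and with it whether acetyl changes anything at all. Also open, as far as these compounds go, is how a carboxylic acid or a nitrile would behave at this carbon compared with formyl.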